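Swapping chloro for fluoro: what compound 4 may show

This account rests on a few compounds, and the source may have more. Where it says the series, first, only, none or still open, it means among the compounds named here.

Measured compounds:
- compound 1 `O=C(O)CCCCC(CCSC(=O)c1ccccc1)SC(=O)c1ccccc1` gives 72.8% in growth inhibition
- compound 2 `O=C(CCCCC(S)CCS)Nc1ccccc1` gives 25.4% in growth inhibition
- compound 3 `O=C(CCCCC(S)CCS)Nc1ccc(Cl)cc1` gives 40.9% in growth inhibition

In a functional assay on NCI-H460 cells (Homo sapiens) for inhibition, read by MTT assay, with a stated time of 24 h, tested at 100 ug/mL (on this read-out higher numbers stand for more inhibition of growth at the one concentration tested and lower numbers for less inhibition of growth), compound 3 gives 40.9% and stands second highest of the three numbers, with compound 2 lower and compound 1 higher. Both gaps lie beyond the usual scatter.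

Compound 4 `O=C(CCCCC(S)CCS)Nc1ccc(F)cc1` differs from compound 3 in one place: fluoro in place of chloro on an aromatic carbon is the whole change, made on an aromatic carbon para to a large group.

For the measured compounds named here, one measured step bears on this change. It is a number 15.5 percentage points higher from compound 2 to compound 3 (beyond the scatter) for chloro in place of hydrogen on an aromatic carbon, and it is modest in size. Going by the values given here, no measured pair swaps chloro for fluoro, so the data do not settle the direction. Part of that modest rise may be lost, which would move compound 4 slightly toward compound 2 at 25.4% on this measure.

The estimated step is a number 4.9 percentage points lower from compound 3 to compound 4 (within the scatter) and it is expected to stay small, with no clear move beyond the scatter. For compound 4 the estimated value is 36% with an expected range from 22% to 52% in this read-out.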

Compound 4, percent growth inhibition at one concentration: 41.6%
Beside the measured number, compound 4's estimate is 5.6 percentage points below it; the range from low to high includes it.
By their numbers in this assay, from the lowest: compound 2; then compounds 3 and 4 (each within the scatter of the next); then compound 1.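

In this assay the swap of halogens gives a number 0.7 percentage points higher from compound 3 to compound 4 (within the scatter) and so, on this aromatic carbon para to a large group, fluoro and chloro cannot be told apart. Set against hydrogen at the same place, fluoro gives a number 16.2 percentage points higher from compound 2 to compound 4 (beyond the scatter) and this stands alongside the earlier a number 15.5 percentage points higher from compound 2 to compound 3 (beyond the scatter) so the rise is no longer tied to chloro alone, although it rests on just these two halogens. Nothing available here explains why the two halogens read alike or why either reads differently from hydrogen.

Going by these compounds, what remains open is whether a halogen is needed at all for this rise, since a methoxy group, a nitrile or an amine at the same place would test whether other groups give a similar reading. It also stays unclear how far the rise carries beyond this one place on the ring and this single tested concentration, and compound 1 differs from these amides in more than one place, so its higher reading says nothing direct about this position.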